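This account rests on a few compounds, and the source may have more. Where it says the series, first, only, none or still open, it means among the compounds named here.

Measured so far:
compound 1, `Cc1ccc(-c2cs/c(=N/NC(=O)CSc3nnnn3C)n2-c2ccccc2)cc1`: 44.3%
compound 2, `COc1ccc(-c2cs/c(=N/NC(=O)CSc3nnc(C)s3)n2-c2ccccc2)cc1`: 31.5%

In a functional assay on C6 cells (Rattus norvegicus) for cytotoxicity, read by MTT assay, with a stated time of 24 h, tested at 50 ug/mL (on this read-out lower numbers stand for a stronger effect and higher numbers for a weaker effect at the one concentration tested), compound 2 gives 31.5%, the lowest of the two numbers. The nearest, compound 1, gives 44.3%, a number higher by a margin that lies beyond the usual scatter of this measurement. Compound 3, `Cc1ccc(-c2cs/c(=N/NC(=O)CSc3nnc(C)s3)n2-c2ccccc2)cc1`, has not yet been measured. It differs from compound 2 in one place: methyl in place of methoxy on an aromatic carbon. For the measured compounds named here, compound 1 also carries a methyl rather than a methoxy, but it differs from compound 2 elsewhere as well, so no single step between measured compounds shows how this change alone acts. In this assay only a modest step is expected, if any, more likely toward a weaker effect than a stronger one, and not clearly beyond the scatter. Compound 3 is therefore expected to give about 38%, within 25% to 52%, which means an expected step of a number 6.5 percentage points higher from compound 2 to compound 3 (within the scatter).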

Compound 3, a percentage reported as activity, at one concentration (the size of the read-out at that concentration, not a potency): 40.6%
Compound 3: the middle estimate sits 2.6 percentage points below what was measured, and the stated range covers the measured number.
By their numbers in this assay, from the lowest: compounds 2, 3 and 1 (each within the scatter of the next, the first and the last beyond it).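

In this assay, methyl in place of methoxy on the aromatic carbon para to a large group, the change from 4-methoxyphenyl to 4-methylphenyl, gives a number 9.1 percentage points higher from compound 2 to compound 3 (within the scatter) and so cannot be told apart from no change at this position. With 5-methyl-1,3,4-thiadiazol-2-yl in place of 1-methyl-1H-tetrazol-5-yl on the sulfur, the result is a number 3.7 percentage points lower from compound 1 to compound 3 (within the scatter) and this exchange is likewise not distinguishable from no change. No supporting measurement is available to explain either result.

The compounds shown leave open how an amine, a hydroxyl group or a longer chain such as butoxy would read at the same aromatic carbon. They also leave open how a carboxylic acid or an open alkyl chain would read on the sulfur in place of these two rings.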